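Piperidine to pyrrolidine on the dithiocarbamate of compound 1

A few compounds are considered here, and "the series" means these few. Any claim that something is new, unique, unknown or untested is made for them only; others in the source may bear on it.

Three members of the series have been tested in a functional assay on LM7 cells (Homo sapiens) for antiproliferative activity, read by MTT assay, with a stated time of 72 h (a higher number here means a weaker inhibitor, a lower number a stronger inhibitor), and only one of them returns a number. Going by the values given here, compound 1 `Cc1ccc2c(=O)c(CSC(=S)N3CCCCC3)coc2c1` gives 5100 nM in this assay, the sole measured value. The other two entries in this assay do not return a number. Compound 2 `CCOC(=O)c1cc(=O)c2cc(CSC(=S)N(C)c3ccccc3)ccc2o1` sits at a limit in this assay, > 25000 nM, a limit of the assay and not a number, consistent with the limit of > 25000 nM in this assay, at which 1 of the 3 values shown sits. Compound 3 `COc1ccc2occ(CSC(=S)N3CCOCC3)c(=O)c2c1` likewise sits at a limit in this assay, > 40000 nM, again a limit and not a number, as in the limit of > 40000 nM in this assay, at which 1 of the 3 values shown sits. No pair among these three differs in a single place, so no measured step is available for the series.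

Compound 4 `Cc1ccc2c(=O)c(CSC(=S)N3CCCC3)coc2c1` is the next entry, not yet tested in this assay. Relative to compound 1 the change is pyrrolidin-1-yl in place of piperidin-1-yl on a thiocarbonyl carbon, in words pyrrolidin-1-yl in place of piperidin-1-yl on a thiocarbonyl carbon. Among the compounds with values here, with no measured step to lean on, the expected step from compound 1 to compound 4, a 1.2-fold higher number from compound 1 to compound 4 (0.07 log units; within the scatter), is taken to lie within the usual scatter, with no direction asserted. Compound 4 is therefore estimated at 6000 nM in this assay, with an expected range from 2500 nM to 15000 nM.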

Compound 4, half-maximal inhibitory concentration: 3400 nM
Compound 4: the middle estimate sits 1.8-fold (0.25 log units) above what was measured, and the stated range covers the measured number.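

The series now has its first measured step at a single place, in this assay: a 1.5-fold lower number from compound 1 to compound 4 (0.18 log units; within the scatter). On a thiocarbonyl carbon whose other neighbours are sulfur, pyrrolidin-1-yl in place of piperidin-1-yl therefore leaves the read-out within the scatter, and compound 4 joins compound 1 as a second member of the series to return a number and not a limit. Going by these compounds alone, nothing measured so far accounts for this step, and the two limits held by other members do not bear on it, since those compounds differ from compound 1 and compound 4 in more than one place.

This single step cannot show how far the amine part can change at this place, and azepan-1-yl or an open-chain diethylamino group on the same thiocarbonyl carbon of the core of compound 1 would extend the comparison. What a morpholine ring alone does on that core also stays open, as the only compound shown with that ring, compound 3, differs from compound 1 elsewhere as well.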